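Exchanging a Side Chain for Carbamoyl: Expected Solubility

The source may report more compounds than this note shows. Statements on the series, on what has been measured and on what is new or still open speak of the compounds shown alone.

Compound 1 `O=C1O[C@@H](CO)CN1c1ccc(-n2cc(-c3ccccn3)cn2)c(F)c1`: 56400 nM
Compound 2 `O=C1CCC(=O)N1C[C@H]1CN(c2ccc(-n3cc(-c4ccccn4)cn3)c(F)c2)C(=O)O1`: 45300 nM
Compound 3 `O=C1CSC(=O)N1C[C@H]1CN(c2ccc(-n3cc(-c4ccccn4)cn3)c(F)c2)C(=O)O1`: 26900 nM

Among the compounds with values here, in a physicochemical assay for solubility, read by HPLC, with a stated time of 24 h (on this read-out lower numbers stand for lower solubility and higher numbers for higher solubility), compound 3 gives 26900 nM, the lowest of the three numbers measured so far. Its nearest neighbour is compound 2, with a 1.7-fold lower number from compound 2 to compound 3 (0.23 log units; within the scatter); its furthest is compound 1, with a 2.1-fold lower number from compound 1 to compound 3 (0.32 log units; beyond the scatter). Compound 4 `NC(=O)[C@H]1CN(c2ccc(-n3cc(-c4ccccn4)cn3)c(F)c2)C(=O)O1` differs from compound 3 in one place: carbamoyl in place of (2,4-dioxo-1,3-thiazolidin-3-yl)methyl on a saturated ring carbon.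

Within the data shown here, two measured steps bear on this change. Going from compound 1 to compound 3, a 2.1-fold lower number from compound 1 to compound 3 (0.32 log units; beyond the scatter), the hydroxy group was exchanged for the 2,4-dioxo-1,3-thiazolidin-3-yl group, and the number fell modestly. Going from compound 2 to compound 3, a 1.7-fold lower number from compound 2 to compound 3 (0.23 log units; within the scatter), one ring-bearing group was exchanged for another and the number stayed within the scatter. Among the measured compounds shown here, the step to compound 4 removes the whole (2,4-dioxo-1,3-thiazolidin-3-yl)methyl group and puts a small carbamoyl group with one hydrogen-bond donor in its place, a change in the opposite sense to the one from compound 1 to compound 3 and larger in what leaves. Compound 4 is therefore expected to show a rise in this assay, of about a 2.6-fold higher number from compound 3 to compound 4 (0.42 log units; beyond the scatter). The estimate for compound 4 is 70000 nM, with a range from 30000 nM to 160000 nM.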

Compound 4, solubility: 27200 nM
Compound 4: the middle estimate sits 2.6-fold (0.41 log units) above what was measured; the measured number lies below the stated range.
By their numbers in this assay, from the lowest: compounds 3, 4, 2 and 1 (each within the scatter of the next, the first and the last beyond it).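

On this saturated ring carbon, carbamoyl in place of (2,4-dioxo-1,3-thiazolidin-3-yl)methyl gives a 1.0-fold higher number from compound 3 to compound 4 (0.00 log units; within the scatter) in this assay even though 8 heavy atoms and a ring leave and only 3 heavy atoms enter, so a much smaller group with no ring can give a number that cannot be told apart from that of the larger ring-bearing group. The same reading holds against (2,5-dioxopyrrolidin-1-yl)methyl, with a 1.7-fold lower number from compound 2 to compound 4 (0.22 log units; within the scatter) and again no order to be drawn, whereas carbamoyl in place of hydroxymethyl gives a 2.1-fold lower number from compound 1 to compound 4 (0.32 log units; beyond the scatter) as a modest step beyond the scatter, so the size of the group at this position does not by itself track the number in these compounds, and compound 2 stays within the scatter of compound 1 despite its larger group. Nothing measured here accounts for this result.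

The compounds shown leave open where a carboxylic acid, an aminomethyl group or a longer chain ending in carbamoyl on this ring carbon would fall in this assay relative to compound 1 and compound 4. They also leave open whether a methyl group on the amide nitrogen of the carbamoyl would shift the number.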